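The compounds below may be only part of what the source reports. "The series", "measured", "known", "first", "only" and "open" are said of these compounds alone.

Measured so far:
- Compound 1, `CCCn1c(=O)[nH]c2nc(-c3ccc(S(=O)(=O)N4CCN(c5ccc(Br)cc5)CC4)cc3)[nH]c2c1=O`: 0.0835 nM
- Compound 2, `CCCn1c(=O)[nH]c2nc(-c3ccc(S(=O)(=O)N4CCN(Cc5cccc(Br)c5)CC4)cc3)[nH]c2c1=O`: 0.148 nM
- Compound 3, `CCCn1c(=O)[nH]c2nc(-c3ccc(S(=O)(=O)N4CCN(c5ccccc5)C(C)C4)cc3)[nH]c2c1=O`: 7.15 nM

These three share one core and differ only in the group carried on the amine nitrogen in the ring at the far end. In an assay on CHO cells for displacement of a labelled ligand from adenosine receptor A2b (Homo sapiens), read by scintillation counting, with a stated time of 75 min, in the presence of a further agent that is not named here (on this read-out higher numbers stand for weaker inhibition and lower numbers for stronger inhibition), compound 2 gives the second highest of the three numbers; its nearest neighbour is compound 1, a gap that lies within the usual scatter, and the furthest is compound 3, a gap well beyond it. Compound 3 differs from compound 2 in more than one place, so only its two values are shown, with no single step to draw on.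

Compound 4, `CCCn1c(=O)[nH]c2nc(-c3ccc(S(=O)(=O)N4CCN(Cc5ccc(Br)cc5)CC4)cc3)[nH]c2c1=O`, has not yet been measured. It differs from compound 2 only in 4-bromophenyl in place of 3-bromophenyl on a saturated chain carbon bound to an amine nitrogen in a ring. Within the data shown here, the one measured step that touches the same region is a 1.8-fold higher number from compound 1 to compound 2 (0.25 log units; within the scatter), which moved the bromine and inserted the extra carbon together and stayed within the scatter. Nothing here separates the position of the bromine on its own, so no shift beyond the scatter is expected from compound 2 to compound 4 in this assay.

Compound 4 is therefore expected to give about 0.12 nM, with a likely range from 0.04 nM to 0.4 nM; this estimate means a 1.2-fold lower number from compound 2 to compound 4 (0.09 log units; within the scatter).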

Compound 4, inhibition constant: 0.153 nM
For compound 4 the middle estimate is 1.3-fold (0.11 log units) below the measured one, within the range that was stated.
By their numbers in this assay, from the lowest: compounds 1, 2 and 4 (each within the scatter of the next); then compound 3.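

In this assay, the swap of 3-bromobenzyl for 4-bromobenzyl gives a 1.0-fold higher number from compound 2 to compound 4 (0.01 log units; within the scatter), so the position of the bromine, which the earlier step could not separate from the added carbon, can now be read on its own, and it shifts the number by no more than the usual scatter. The second step, a 1.8-fold higher number from compound 1 to compound 4 (0.26 log units; within the scatter), keeps the 4-bromo pattern and changes only 4-bromophenyl to 4-bromobenzyl, so the extra carbon alone also stays within the scatter. No measurement is available here that would explain these results.

From the compounds shown here alone, all of these comparisons involve bromine, so it remains open whether a carboxylic acid or an amine in its place would keep the number this low. A longer chain between the amine nitrogen and the aromatic ring is also untested among the compounds shown.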